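Aryl hydrazone series: methyl to methoxy on the phenyl ring

The source may hold more compounds than are shown below. What is called first, only, known or untested is meant among the compounds shown, and "the series" means these compounds.

Compound 2 `Cc1ccc(-c2csc(N/N=C/c3ccc(Cl)cc3Cl)n2)cc1` is the reference for this note. In a functional assay, read by spectrophotometry, with a stated time of 15 min, tested at 40 ug/mL (on this read-out lower numbers stand for a weaker effect and higher numbers for a stronger effect at the one concentration tested), compound 2 gives 80.4%, the lowest of the three numbers in hand, though within the scatter of both neighbours. Compound 3 `Fc1ccc(-c2csc(N/N=C/c3cccs3)n2)cc1` gives 87.5% in this assay, and compound 1 `Fc1ccc(-c2csc(N/N=C/c3ccc(Cl)cc3Cl)n2)cc1` gives 90%. Among the measured compounds shown here, the only single-place step measured, a number 9.6 percentage points lower from compound 1 to compound 2 (within the scatter), exchanges fluoro for methyl and stays within the scatter.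

Compound 4 `COc1ccc(-c2csc(N/N=C/c3ccc(Cl)cc3Cl)n2)cc1` differs from compound 2 in one place: methoxy in place of methyl on an aromatic carbon. For the measured compounds named here, no measured pair exchanges methyl for methoxy, so the one step in hand, a number 9.6 percentage points lower from compound 1 to compound 2 (within the scatter), bears on compound 4 only by showing that a change at the same place on the shared core left the read-out within the scatter. On that basis no step beyond the scatter is expected in this assay in either direction, and the estimated step of a number 2.6 percentage points higher from compound 2 to compound 4 (within the scatter) is expected to stay within the scatter. Compound 4 is therefore estimated at 83% in this assay, with a range from 70% to 93%.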

Compound 4, a percentage reported as inhibition, at one concentration (the size of the read-out at that concentration, not a potency): 79.7%
Compound 4: middle estimate off by 3.3 percentage points, on the high side; the range from low to high includes it.
By their numbers in this assay, from the lowest: compounds 4, 2, 3 and 1 (each within the scatter of the next, the first and the last beyond it).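

In this assay, methoxy in place of methyl at this place, para to a large group, gives a number 0.7 percentage points lower from compound 2 to compound 4 (within the scatter), so adding an oxygen and a hydrogen-bond acceptor to the 4-methylphenyl group does not separate these two compounds. Methoxy in place of fluoro gives a number 10.3 percentage points lower from compound 1 to compound 4 (beyond the scatter), the first modest step beyond the scatter at this position, whereas compound 2 remains within the scatter of compound 1. No measured evidence accounts for either step.

From the compounds shown here alone, whether an amine, a carboxylic acid or a longer chain such as ethoxy at this place would move the read-out beyond the scatter remains open. Also open, going by these compounds, is whether methoxy in place of fluoro would give a similar step on the core of compound 3.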